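A few compounds are considered here, and "the series" means these few. Any claim that something is new, unique, unknown or untested is made for them only; others in the source may bear on it.

Measured so far:
compound 1, `Cc1ccc(S(=O)(=O)N2N=C(c3ccc(-n4cncn4)cc3)CC2c2ccc(N(C)C)cc2)cc1`: 20%
compound 2, `CN(C)c1ccc(C2CC(c3ccc(-n4ccnc4)cc3)=NN2C(=O)CCCl)cc1`: -2.5%
compound 3, `COC(=O)CC(=O)N1N=C(c2ccc(-n3ccnc3)cc2)CC1c1ccc(N(C)C)cc1`: -0.1%

All three numbers come from a functional assay on NCI-H1975 cells (Homo sapiens) for inhibition, read by sulforhodamine B assay, tested at 10 uM; on this read-out higher numbers stand for more inhibition at the one concentration tested (going by the name of the read-out) and lower numbers for less inhibition. Compound 3 stands in the middle of the three: compound 1 gives 20%, which lies beyond the scatter above the value of compound 3, while compound 2 gives -2.5%, within the scatter of compound 3. Within the data shown here, the one single-place step measured so far is a number 2.4 percentage points higher from compound 2 to compound 3 (within the scatter), a change on the chain attached to the ring nitrogen, and it stays within the scatter.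

Compound 4, `Cc1ccc(S(=O)(=O)N2N=C(c3ccc(-n4ccnc4)cc3)CC2c2ccc(N(C)C)cc2)cc1`, is not yet measured. It differs from compound 3 in one place: (4-methylphenyl)sulfonyl in place of ((methoxycarbonyl)methyl)carbonyl on an amine nitrogen in a ring. The measured step concerns a different change and so does not bear on this one directly. Among the measured compounds shown here, the (4-methylphenyl)sulfonyl group entering here is also present in compound 1, but compound 1 differs from compound 4 in a second place as well, so no single-place step is known for it; what can be said is that compound 1 gives 20%, the highest of the three numbers. On this basis an upward step of a number 15.1 percentage points higher from compound 3 to compound 4 (beyond the scatter) is expected, though with wide uncertainty. In this assay compound 4 is therefore estimated at 15%, with a range from 0% to 30%.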

Compound 4, a percentage reported as inhibition, at one concentration (the size of the read-out at that concentration, not a potency): 50.5%
Compound 4: the middle estimate sits 35.5 percentage points below what was measured; the measured number lies above the stated range.
By their numbers in this assay, from the lowest: compounds 2 and 3 (each within the scatter of the next); then compound 1; then compound 4.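

In this assay the amine nitrogen in the ring turns out to be a sensitive position: with (4-methylphenyl)sulfonyl in place of ((methoxycarbonyl)methyl)carbonyl the series shows a number 50.6 percentage points higher from compound 3 to compound 4 (beyond the scatter) and, against (2-chloroethyl)carbonyl, it shows a number 53 percentage points higher from compound 2 to compound 4 (beyond the scatter) on the same nitrogen. Among these compounds, the only earlier single-place step, a number 2.4 percentage points higher from compound 2 to compound 3 (within the scatter) between two carbonyl-linked chains, gave no sign of a change of this size. The aromatic carbon also matters with (4-methylphenyl)sulfonyl held fixed, as 1H-imidazol-1-yl in place of 1H-1,2,4-triazol-1-yl gives a number 30.5 percentage points higher from compound 1 to compound 4 (beyond the scatter), so the number depends on more than the group on the ring nitrogen. Nothing available explains either effect.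

The entering group brings a sulfonyl link and a 4-methylphenyl ring together, so a methylsulfonyl or a benzoyl group on the same nitrogen would be needed to tell which part carries the gain. It also remains open whether the preference for 1H-imidazol-1-yl over 1H-1,2,4-triazol-1-yl holds with carbonyl-linked chains on the nitrogen, and a reading at one concentration gives no potency for any of these compounds.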